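A Longer Chain on a Sparsely Measured Quinone-Like Core

The source may report more compounds than this note shows. Statements on the series, on what has been measured and on what is new or still open speak of the compounds shown alone.

Among the compounds with values here, only one firm number anchors this small series. In a functional assay on M109 cells (Mus musculus) for cytotoxicity (a lower number here means a stronger inhibitor, a higher number a weaker inhibitor), compound 1 (`CCCCCCCC1=CC(=O)C=C(OC)C1=O`) gives 10 ug/mL as its result. Compound 2 (`COC1=CC(=O)C=C(C)C1=O`) has the entry "not determined" (no result reported) in the same test. Compound 3 (`CCCCC1=CC(=O)C=C(OC)C1=O`) also stands at "not determined" (no result reported) and therefore offers no single number as a starting point.

The next compound to be tested is compound 4 (`CCCCCCCCCCC1=CC(=O)C=C(OC)C1=O`). Its structure differs from that of compound 3 by one change, hexyl in place of hydrogen on a saturated chain carbon, four bonds along the chain from a double-bonded ring carbon on the shared core, and the side chain becomes longer as a result.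

Within the data shown here, no two measured compounds differ in just one place, so the size of a single structural step cannot be read from the data. Among the measured compounds shown here, the only guide is compound 1 at 10 ug/mL and its chain is longer than that of compound 3 and shorter than that of compound 4. With one number, no trend with chain length can be established. The expectation is therefore that compound 4 will differ from compound 1 by no more than the usual scatter of repeated measurements in this assay and that no direction can be favoured. The estimated value for compound 4 is 8 ug/mL with an expected range of 2 ug/mL to 30 ug/mL in this test.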

Compound 4, half-maximal inhibitory concentration: 10 ug/mL
For compound 4 the middle estimate is 1.3-fold (0.10 log units) below the measured one; the measured number falls inside the stated range.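

The series now has its first readable step: in this assay there is no change at the digits printed from compound 1 to compound 4 (within the scatter) with propyl in place of hydrogen on a saturated chain carbon, seven bonds along the chain from a double-bonded ring carbon. At this position, then, the longer chain of compound 4 cannot be told apart from the shorter chain of compound 1 in this test, which is more than a single number could show; compound 3 has no number, so its step to compound 4 cannot be read. Nothing on hand offers an explanation for this flat result.

As far as these compounds go, two compounds with matching values do not make a trend, so it remains open whether a still longer chain, such as dodecyl, would give the same result in this test. From the compounds shown here alone, it is also open whether a carboxylic acid or an amine placed on the chain would leave the result unmoved, as the added propyl did, or would shift it.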